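The source may hold more compounds than are shown below. What is called first, only, known or untested is meant among the compounds shown, and "the series" means these compounds.

Measured so far:
compound 1, `CC(=O)Nc1ccc(/C=N/Nc2nc(N)c3ncn([C@@H]4O[C@H](CO)[C@@H](O)[C@H]4O)c3n2)cc1`, gives 0%
compound 2, `Nc1nc(N/N=C/c2ccc(N(c3ccccc3)c3ccccc3)cc2)nc2c1ncn2[C@@H]1O[C@H](CO)[C@@H](O)[C@H]1O`, gives 0%

Both of these compounds were tested in an assay on CHO-K1 cells for displacement of a labelled ligand from adenosine receptor A1 (Homo sapiens), read by scintillation counting, with a stated time of 60 min, tested at 1 uM; on this read-out higher numbers stand for more inhibition at the one concentration tested (going by the name of the read-out) and lower numbers for less inhibition. Compound 1 gives 0% and compound 2 gives 0%, so compound 1 stands level with compound 2 at the digits shown, with no difference beyond the usual scatter of this kind of measurement. Neither compound displaces the labelled ligand to any measurable degree at the concentration used.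

Compound 3, `CN(C)c1ccc(/C=N/Nc2nc(N)c3ncn([C@@H]4O[C@H](CO)[C@@H](O)[C@H]4O)c3n2)cc1`, has not yet been measured in this assay. It differs from compound 1 in one place: dimethylamino in place of acetamido on an aromatic carbon. Going by the values given here, no step between two measured compounds is available to show what such an exchange does here; the only guide is that compound 1 and compound 2, which carry quite different groups at the same part of the molecule, both give no measurable inhibition.

On that basis the step from compound 1 to compound 3 is expected to be a number 3 percentage points higher from compound 1 to compound 3 (within the scatter), none beyond the scatter. Compound 3 is estimated to give 3%, with a range from 0% to 20%.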

Compound 3, a percentage reported as inhibition, at one concentration (the size of the read-out at that concentration, not a potency): 0%
Beside the measured number, compound 3's estimate is 3 percentage points above it, and the stated range covers the measured number.
By their numbers in this assay, from the lowest: compounds 1, 2 and 3 (each within the scatter of the next).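

In this assay, putting dimethylamino in place of acetamido on an aromatic carbon, para to a large group, gives no change at the digits printed from compound 1 to compound 3 (within the scatter). Going by these compounds alone, this is the first step that can be read at this position, and it shows that the hydrogen-bond donor of acetamido can leave and a group without one can enter, with no measurable inhibition appearing at the one concentration tested. Since compound 1 and compound 3 both sit at zero, the step can only show that dimethylamino brings no detectable gain, and no measurement here explains this result.

The compounds shown leave open whether any group on this aromatic carbon can lift inhibition above zero, such as a carboxylic acid, a hydroxyl group or a longer chain ending in an amine. They also leave open whether compound 1 and compound 3 truly differ at all, since a reading of zero at a single concentration cannot separate two compounds that might diverge at higher concentrations.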